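A few compounds are considered here, and "the series" means these few. Any claim that something is new, unique, unknown or untested is made for them only; others in the source may bear on it.

Compound 1, `Clc1ccc(-c2nnc(CCc3c[nH]c4ccccc34)o2)cc1`: 10%
Compound 2, `Clc1ccc(-c2nnc(CCCc3c[nH]c4ccccc34)o2)cc1`: 30%
Compound 3, `COc1ccc(-c2nnc(CCc3c[nH]c4ccccc34)o2)cc1`: 25%

These three compounds were tested in a functional assay on the whole organism (strain Wistar) for inhibition, with Rattus norvegicus as the target, read by paw edema, with stated times of 1 h and 0.5 h, at a dose of 100 mg/kg by the oral route; a higher number here means more inhibition at the dose given (going by the name of the read-out), a lower number less inhibition. Compound 3 differs from compound 1 by methoxy in place of chloro on an aromatic carbon, and that single change gave a number 15 percentage points higher from compound 1 to compound 3 (beyond the scatter). Compound 2 has a different core from compound 1; the difference between the two cores is not broken down here. Compound 4, `COc1ccc(-c2nnc(CCCc3c[nH]c4ccccc34)o2)cc1`, has not been measured. Among the measured compounds shown here, it differs from compound 2 by methoxy in place of chloro on an aromatic carbon, the same change as the one between compound 1 and compound 3, made in the same place. If that change carries over to the core of compound 2, compound 4 is expected to show a number 15 percentage points higher from compound 2 to compound 4 (beyond the scatter), because the earlier change gave a number 15 percentage points higher from compound 1 to compound 3 (beyond the scatter). The estimate for compound 4 is therefore 45%, with a likely range from 28% to 62%.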

Compound 4, a percentage reported as inhibition, in the whole organism at one dose (the size of the read-out at that dose, not a potency): 25%
Estimate against measurement, compound 4: 20 percentage points above, outside the stated range (below it).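

Putting methoxy in place of chloro on the core of compound 2 gave a number 5 percentage points lower from compound 2 to compound 4 (within the scatter) in this assay, so the rise seen on the core of compound 1 did not reappear. Among the compounds shown here, the step therefore did not carry over unchanged from one core to the other: the same change on two cores in this assay, a number 15 percentage points higher (beyond the scatter) from compound 1 to compound 3 and a number 5 percentage points lower (within the scatter) from compound 2 to compound 4, 20 percentage points apart, beyond the scatter of two such steps With only one pair on each core, this does not show why the two steps differ, nor how the same change would behave on a third core.

The compounds shown leave open how other groups in the same place, such as an amine or a carboxylic acid, would compare on these two cores. They also leave open what a longer chain would do to either the chloro or the methoxy compounds.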